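This account rests on a few compounds, and the source may have more. Where it says the series, first, only, none or still open, it means among the compounds named here.

Working notes on the series. In an ADME assay on HEK-293T cells (Homo sapiens) for inhibition, read by CCK-8 assay, with a stated time of 48 h, tested at 20 uM (a lower number here means less inhibition of growth, a higher number more inhibition of growth at the concentration tested), compound 1 `COc1ccc(Cc2nnc(NC(=O)/C(C#N)=C/c3ccccc3OS(=O)(=O)c3ccc(Cl)cc3)s2)cc1` gives 34% and compound 2 `COc1ccc(Cc2nnc(NC(=O)/C(C#N)=C/c3ccccc3OS(=O)(=O)c3ccc(F)cc3)s2)cc1` gives 6%, which leaves compound 1 with the higher of the two numbers. Compound 3 `N#C/C(=C\c1ccccc1OS(=O)(=O)c1ccc(Cl)cc1)C(=O)Nc1nnc(-c2cccc(F)c2)s1` has not yet been measured. The change is 3-fluorophenyl in place of 4-methoxybenzyl on an aromatic carbon of a five-membered aromatic ring with 2 nitrogen and 1 sulfur. Among the compounds with values here, only one measured step is available, a number 28 percentage points lower from compound 1 to compound 2 (beyond the scatter), with fluoro in place of chloro on an aromatic carbon. That step lies elsewhere in the molecule and bears on this change only indirectly, showing that a single substitution can move the number in this assay by that amount. Within the data shown here, no measured step covers loss of the 4-methoxybenzyl group, so the direction is weakly held, and a modest fall is expected, no larger than the one measured. The expected step is a number 9 percentage points lower from compound 1 to compound 3 (within the scatter). For compound 3 the estimated value is 25%, with an expected range of 5% to 52%.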

Compound 3, percent growth inhibition at one concentration: 29%
Estimate against measurement, compound 3: 4 percentage points below, within the range that was stated.
By their numbers in this assay, from the lowest: compound 2; then compounds 3 and 1 (each within the scatter of the next).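

In this assay, within the data shown here, the exchange of 4-methoxybenzyl for 3-fluorophenyl on the aromatic carbon of the five-membered aromatic ring with 2 nitrogen and 1 sulfur gives a number 5 percentage points lower from compound 1 to compound 3 (within the scatter) and is the first reading at this position. The earlier step, a number 28 percentage points lower from compound 1 to compound 2 (beyond the scatter), lay at the chloro elsewhere in the molecule; this pair shows that the position can take a different aromatic group, without the benzyl carbon or the methoxy oxygen, with no change beyond the scatter in this assay at the concentration tested. The data offer no independent measurement that would explain why this pair reads alike.

This single pair cannot show whether the position is generally tolerant, and a group of another kind there, such as an amine, a carboxylic acid or a longer chain, could still hold the number or move it beyond the scatter. Going by these compounds, it also remains open whether the drop seen on going from chloro to fluoro in the 4-methoxybenzyl pair would recur with 3-fluorophenyl at this position.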